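This account rests on a few compounds, and the source may have more. Where it says the series, first, only, none or still open, it means among the compounds named here.

Compound 1 `CCCc1ccccc1OS(=O)(=O)c1cccc(NC(=O)NCCCCl)c1` gives 14000 nM in a functional assay on HT-29 cells (Homo sapiens) for cytotoxicity, read by sulforhodamine B assay, with a stated time of 48 h; a lower number here means a stronger inhibitor, a higher number a weaker inhibitor.
Compound 2 `Cc1ccccc1NS(=O)(=O)c1cccc(NC(=O)NCCCCl)c1` gives 42000 nM in this assay.
Compound 3 `CCCc1ccccc1OS(=O)(=O)c1cccc(NC(=O)NCC)c1` gives 25000 nM in this assay.

Compound 3 differs from compound 1 by one change, (hydrogen in place of chloromethyl on a saturated chain carbon, two bonds along the chain from an amide-type nitrogen), and the step that went with it, a 1.8-fold higher number from compound 1 to compound 3 (0.25 log units; within the scatter), stays within the scatter. Compound 2 carries a different core; the difference between the two cores is not broken down here. Compound 2 has the highest number of the three, and only its gap to compound 1 lies beyond the scatter.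

Compound 4 `CCNC(=O)Nc1cccc(S(=O)(=O)Nc2ccccc2C)c1` has not yet been measured. It stands to compound 2 as compound 3 stands to compound 1: the change is hydrogen in place of chloromethyl on a saturated chain carbon, two bonds along the chain from an amide-type nitrogen, at the same place in the same words, so it is the same change. Because the earlier step of a 1.8-fold higher number from compound 1 to compound 3 (0.25 log units; within the scatter) was small, a step of similar size, a 1.7-fold higher number from compound 2 to compound 4 (0.22 log units; within the scatter), is expected from compound 2 to compound 4 in this assay. Compound 4 is therefore estimated at 70000 nM, with a likely range from 30000 nM to 160000 nM.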

Compound 4, half-maximal inhibitory concentration: 102000 nM
For compound 4 the middle estimate is 1.5-fold (0.16 log units) below the measured one, and the stated range covers the measured number.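

Going from 3-chloropropyl to ethyl on the core of compound 2 gives a 2.4-fold higher number from compound 2 to compound 4 (0.39 log units; beyond the scatter) in this assay. Set beside the earlier step, the change carries from one core to the other with no difference in size that can be told from the scatter: the same change on two cores in this assay, a 1.8-fold higher number (0.25 log units; within the scatter) from compound 1 to compound 3 and a 2.4-fold higher number (0.39 log units; beyond the scatter) from compound 2 to compound 4, 1.4-fold (0.13 log units) apart, within the scatter of two such steps. For the compounds shown here, this rests on only two pairs of compounds in one cell assay, so it does not show that the change would behave alike on any further core, nor why the number moves.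

The compounds shown leave open how a longer chain, an amine or a carboxylic acid in place of the chloromethyl would read in this assay. They also do not break down the difference between the two cores.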